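Benzyl for phenyl on the oxygen: working notes

The compounds below may be only part of what the source reports. "The series", "measured", "known", "first", "only" and "open" are said of these compounds alone.

compound 1 `Cc1[nH]c(=O)n(C2CCCCC2)c1-c1ccc(OC(C)C)cc1`: 13000 nM
compound 2 `CCCCCCc1ccc(-c2c(C)[nH]c(=O)n2C2CCCCC2)cc1`: 13700 nM
compound 3 `Cc1[nH]c(=O)n(C2CCCCC2)c1-c1ccc(Oc2ccccc2)cc1`: 7900 nM
compound 4 `Cc1[nH]c(=O)n(C2CCCCC2)c1-c1ccc(OCc2ccccc2)cc1`: not yet measured

All measured values come from a functional assay on brain (Rattus norvegicus, strain Wistar) for inhibition; on this read-out lower numbers stand for stronger inhibition and higher numbers for weaker inhibition. Compound 3, at 7900 nM, stands within the scatter of both other measured compounds. The next change is benzyl in place of phenyl on an oxygen on an aromatic ring. The closest evidence is a 1.6-fold lower number from compound 1 to compound 3 (0.22 log units; within the scatter), a change on the same oxygen. Also relevant is a 1.7-fold lower number from compound 2 to compound 3 (0.24 log units; within the scatter). Both steps stay within the scatter, so no step beyond the scatter is expected in this assay. The expected step is a 1.1-fold higher number from compound 3 to compound 4 (0.06 log units; within the scatter). For compound 4 the estimated value is 9000 nM, with an expected range of 3500 nM to 20000 nM.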

Compound 4, half-maximal inhibitory concentration: 8300 nM
For compound 4 the middle estimate is 1.1-fold (0.04 log units) above the measured one; low and high end bracket the measured number.
By their numbers in this assay, from the lowest: compounds 3, 4, 1 and 2 (each within the scatter of the next).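

In this assay, benzyl on the oxygen on the aromatic ring reads the same as phenyl (a 1.1-fold higher number from compound 3 to compound 4 (0.02 log units; within the scatter)), so the extra carbon of benzyl does not separate the two. Benzyloxy also stays within the scatter against hexyl (a 1.7-fold lower number from compound 2 to compound 4 (0.22 log units; within the scatter)) and against isopropoxy (a 1.6-fold lower number from compound 1 to compound 4 (0.19 log units; within the scatter)), which leaves all four groups at this place without a step beyond the scatter. Nothing at hand accounts for this flat reading.

Still open, going by these compounds, is whether an amine or a carboxylic acid on the benzyl ring would move the number beyond the scatter.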